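This account rests on a few compounds, and the source may have more. Where it says the series, first, only, none or still open, it means among the compounds named here.

Working notes on the series. Compound 1 `CC(C)c1ncn2c(O)nncc12` and compound 2 `CCCc1ncn2c(O)nncc12` share one core; compound 3 `CCn1ncc2c(C)nc(C(C)C)n2c1=O` and the not yet measured compound 4 `CCCc1nc(C)c2cnn(CC)c(=O)n12` share another, and the difference between the two cores is not broken down here. In a functional assay for inhibition, with Homo sapiens as the target (a higher number here means a weaker inhibitor, a lower number a stronger inhibitor), compound 1 gives > 48000 nM, which is a limit of the assay and not a number. In this assay compound 2 gives > 48000 nM, likewise a limit. In this assay compound 3 gives > 48000 nM, again a limit. The change from compound 1 to compound 2, (propyl in place of isopropyl on an aromatic carbon), produced a step that the two limits leave unreadable from compound 1 to compound 2. Compound 4 arises from compound 3 by the same kind of change, (propyl in place of isopropyl on an aromatic carbon); the surroundings differ, since in compound 1 the carbon lies next to the ring nitrogen, two ring bonds from the ring nitrogen, whereas in compound 3 it lies between two ring nitrogen atoms, two ring bonds from the ring atom that bears a methyl group. Among the compounds with values here, every measured value so far sits at the limit of > 48000 nM in this assay, at which 3 of the 3 values shown sit. For compound 4 the expected result is 80000 nM, an estimated step that the limit leaves unreadable from compound 3 to compound 4, with the estimated range running from 48000 nM to 250000 nM. This expectation rests on (the limit of > 48000 nM in this assay, at which 3 of the 3 values shown sit), where compound 3 sits, and on a step that the two limits leave unreadable from compound 1 to compound 2.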

Compound 4, half-maximal inhibitory concentration: > 48000 nM
Compound 4: only a limit was reported; the forecaster's own chance of this, stated with the estimate: 85%; the middle value does not contradict the limit.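

In this assay compound 4 gives > 48000 nM, a limit of the assay and not a number, so no step can be read between compound 3 and compound 4. All the results shown stand at one value: the limit of > 48000 nM in this assay, at which 4 of the 4 values shown sit. The compounds shown leave open whether propyl and isopropyl differ in inhibition on either core.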